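From dimethylamino to piperidin-1-yl: estimating compound 4

The compounds below may be only part of what the source reports. "The series", "measured", "known", "first", "only" and "open" are said of these compounds alone.

In a functional assay on the whole organism with Mus musculus as the target, in the maximal electroshock model (a lower number here means that less compound is needed, a higher number that more compound is needed for the effect), compound 1 `CCCCC(=O)c1ccc2c(c1)sc(=O)n2CCN(C)C` gives 27.3 mg/kg and compound 2 `CCC(=O)c1ccc2c(c1)sc(=O)n2CCN(C)C` gives 21.8 mg/kg so these two sit within the scatter of each other. Compound 3 `CN(C)CCn1c(=O)oc2cc(C(=O)c3ccccc3)ccc21` gives 84.4 mg/kg which is a higher number than both. Compared with compound 2, compound 4 `CCC(=O)c1ccc2c(c1)sc(=O)n2CCN1CCCCC1` carries piperidin-1-yl in place of dimethylamino on a saturated chain carbon, two bonds along the chain from an aromatic nitrogen. Among the measured compounds shown here, the one measured step (a 1.3-fold lower number from compound 1 to compound 2 (0.10 log units; within the scatter)) lies within the scatter and sits elsewhere, two bonds along the chain from a carbonyl carbon. For the measured compounds named here, no measured pair tests this change directly, so no step beyond the scatter is expected. The estimated move is small (a 1.1-fold higher number from compound 2 to compound 4 (0.06 log units; within the scatter)). For compound 4 the expected value is 25 mg/kg with an estimated range from 11 mg/kg to 55 mg/kg in this measure.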

Compound 4, dose for half-maximal effect: 8.7 mg/kg
For compound 4 the middle estimate is 2.9-fold (0.46 log units) above the measured one; the measured number lies below the stated range.
By their numbers in this assay, from the lowest: compound 4; then compounds 2 and 1 (each within the scatter of the next); then compound 3.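

In this assay, piperidin-1-yl in place of dimethylamino brings a 2.5-fold lower number from compound 2 to compound 4 (0.40 log units; beyond the scatter) and so gives the first step beyond the scatter among these single changes. The earlier step, two bonds along the chain from a carbonyl carbon, stayed within the scatter, so this place on the side chain shows a clearer response. Nothing available explains the shift.

Going by these compounds, whether pyrrolidin-1-yl or morpholin-4-yl would move the number the same way remains open. So does the effect of a longer chain between the aromatic nitrogen and the amine.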